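Adding an ethyl group to the amine of compound 2

The compounds below may be only part of what the source reports. "The series", "measured", "known", "first", "only" and "open" are said of these compounds alone.

In a functional assay on HeLa cells (Homo sapiens) for antiproliferative activity, read by MTT assay, with a stated time of 48 h (a higher number here means a weaker inhibitor, a lower number a stronger inhibitor), the measured compounds give:
compound 1 `COc1ccc(C(=O)c2ccc3c(c2)C=CC(C)(C)O3)c(NC(=O)CO)c1`: 240 nM
compound 2 `COc1ccc(C(=O)c2ccc3c(c2)C=CC(C)(C)O3)c(NC(=O)CN)c1`: 580 nM

Compound 2 holds the higher number of the two at 580 nM and so is the weaker inhibitor. Compound 3 `CCNCC(=O)Nc1cc(OC)ccc1C(=O)c1ccc2c(c1)C=CC(C)(C)O2` differs from it by ethyl in place of hydrogen on an amine nitrogen which turns amino into ethylamino. Among the compounds with values here, the only measured step is a 2.4-fold higher number from compound 1 to compound 2 (0.38 log units; beyond the scatter) with amino in place of hydroxy. Within the data shown here, no measured step adds an ethyl, so that modest step is only a loose guide. In this assay the step expected is a 1.0-fold higher number from compound 2 to compound 3 (0.01 log units; within the scatter) with no firm direction. For compound 3 the estimated value is 600 nM with 220 nM to 1600 nM as its expected range.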

Compound 3, half-maximal inhibitory concentration: 3110 nM
The estimate for compound 3 lay 5.2-fold (0.71 log units) below the measured number; measured number above the stated range.
By their numbers in this assay, from the lowest: compound 1; then compound 2; then compound 3.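

In this assay, the amine nitrogen on this chain proves sensitive to substitution: ethyl in place of hydrogen gives a 5.4-fold higher number from compound 2 to compound 3 (0.73 log units; beyond the scatter) and so a weaker inhibitor. Taken together with the earlier change, ethylamino in place of hydroxy gives a 13-fold higher number from compound 1 to compound 3 (1.11 log units; beyond the scatter) and puts the hydroxy and ethylamino compounds far apart on the same core. No measurement offered here explains this loss of activity.

The compounds shown leave open whether methyl on the same nitrogen would also raise the number. A longer chain such as propyl, or a ring amine such as morpholine, also remains an open case.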